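Mirror Image of a Compound Already at the Limit

The source may report more compounds than this note shows. Statements on the series, on what has been measured and on what is new or still open speak of the compounds shown alone.

Compound 2 `O=C(O)[C@@H](CO)NC(=O)[C@H]1C[C@H](O)CN1` gives > 12 h in a physicochemical assay for metabolic stability, read by HPLC, in phosphate buffer, with a stated time of 12 h, at pH 6.8 (a lower number here means that the compound disappears faster, a higher number that the compound lasts longer), which is a limit of the assay and not a number. Compound 1 `O=C(O)[C@@H](CO)NC(=O)[C@H]1C[C@@H](O)CN1` gives > 12 h, also a limit. Compound 3 `O=C(O)[C@H](CO)NC(=O)[C@H]1C[C@@H](O)CN1` gives > 12 h, again a limit. Compound 2 therefore shares its standing with both neighbours, and none can be ranked against the others.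

Compound 4 `O=C(O)[C@H](CO)NC(=O)[C@@H]1C[C@@H](O)CN1` is related to compound 2 as follows: the two compounds have the same atoms and bonds and differ only in configuration as drawn: 3 of 3 stereo elements differ (all stereocentres are inverted: mirror images); a stereocentre at a saturated chain carbon is drawn R in compound 2 and S in compound 4; a stereocentre at a saturated ring carbon is drawn R in compound 2 and S in compound 4; a stereocentre at a saturated ring carbon is drawn S in compound 2 and R in compound 4. It is the mirror image of compound 2, with the same atoms and bonds.

The closest evidence is a step that the two limits leave unreadable from compound 1 to compound 2, a step that the two limits leave unreadable from compound 1 to compound 3 and a step that the two limits leave unreadable from compound 2 to compound 3. Their sizes cannot be read, but none of these changes in configuration brought a compound off the limit. Going by the values given here, one ring stereocentre is inverted here for the first time, so that part remains untested.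

No step beyond the usual scatter is expected in this assay. The expected change is a step that the limit leaves unreadable from compound 2 to compound 4. For compound 4 the estimated half-life is 20 h, with an expected range from 12 h to 40 h, and the result will probably be reported only as a limit.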

Compound 4, half-life: > 12 h
Compound 4 was reported as a limit; the forecaster's own chance of this, stated with the estimate: 90%; the middle value does not contradict the limit.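

In this assay compound 4 gives > 12 h, which is a limit and not a number. Going by these compounds alone, compounds 1, 2 and 3 sit at the same limit, so no step from any of them to compound 4 can be read. On these data alone, how long each of these four compounds actually lasts, and whether they differ at all, remains open.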